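Imidazole substituent swap: benzyl in place of cyclohexyl

The source may report more compounds than this note shows. Statements on the series, on what has been measured and on what is new or still open speak of the compounds shown alone.

Compound 1 `O=C(O)c1ccccc1-c1ccc(CCc2ncc(C3CCCCC3)[nH]2)cc1` gives 14.7 nM in an in vitro functional assay on cells for agonist activity at Bombesin receptor subtype-3 (Mus musculus), read by luminescence and calcium flux (a higher number here means that more compound is needed for the effect, a lower number that less compound is needed), the second highest of the three numbers; compound 3 `CC(C)(C)Cc1cnc(CCc2ccc(-c3ccccc3C(=O)O)cc2)[nH]1` gives 6.3 nM, and compound 2 `N#Cc1ccc(Cc2cnc(CCc3ccc(-c4ccccc4C(=O)O)cc3)[nH]2)cc1` gives 723 nM. Compound 4 `O=C(O)c1ccccc1-c1ccc(CCc2ncc(Cc3ccc(F)cc3)[nH]2)cc1` differs from compound 1 as follows: 4-fluorobenzyl in place of cyclohexyl on an aromatic carbon. The step that bears on this is a 49-fold higher number from compound 1 to compound 2 (1.69 log units; beyond the scatter), where a benzyl group carrying a nitrile replaced the cyclohexyl; the neopentyl step, a 2.3-fold lower number from compound 1 to compound 3 (0.37 log units; beyond the scatter), was modest in the other direction. A benzyl bearing fluorine in place of the nitrile is expected to move the number upward as well, though its size is uncertain, so a step of a 14-fold higher number from compound 1 to compound 4 (1.13 log units; beyond the scatter) is estimated. Compound 4 is therefore expected to give about 200 nM in this assay, within 50 nM to 800 nM.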

Compound 4, half-maximal effective concentration: 50 nM
The estimate for compound 4 lay 4.0-fold (0.60 log units) above the measured number, within the range that was stated.
By their numbers in this assay, from the lowest: compound 3; then compound 1; then compound 4; then compound 2.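

In this assay, the substituent on the benzyl ring at this aromatic carbon decides much of the outcome, with a 14-fold lower number from compound 2 to compound 4 (1.16 log units; beyond the scatter) on going from cyano to fluoro. A benzyl group here is therefore not poor as such: 4-fluorobenzyl in place of cyclohexyl gives only a 3.4-fold higher number from compound 1 to compound 4 (0.53 log units; beyond the scatter) and stays well short of the 4-cyanobenzyl loss. Neopentyl still keeps the lower number, with a 7.9-fold higher number from compound 3 to compound 4 (0.90 log units; beyond the scatter) on moving to 4-fluorobenzyl.

Where an unsubstituted benzyl, or a benzyl carrying a methoxy group or an amine, would fall remains open. Nothing available explains the gap between fluoro and nitrile.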